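The source may hold more compounds than are shown below. What is called first, only, known or untested is meant among the compounds shown, and "the series" means these compounds.

In a functional assay on Bel-7402 cells (Homo sapiens) for cytotoxicity, read by resazurin assay, with a stated time of 72 h (a higher number here means a weaker inhibitor, a lower number a stronger inhibitor), compound 3 `COc1ccc(-c2nnc(CCSC(=S)NCc3cccnc3)o2)cc1` gives 1540 nM, the lowest of the three numbers recorded. Compound 2 `S=C(NCc1cccnc1)SCCc1noc(-c2ccccc2)n1` gives 2800 nM, a number within the scatter of that of compound 3, while compound 1 `NC(=O)CCSC(=S)NCc1cccnc1` gives 3330 nM, a number beyond the scatter above compound 3. Compound 4 `S=C(NCc1cccnc1)SCCc1nnc(-c2cnccn2)o1` has not yet been measured in this assay. It differs from compound 3 in one place: pyrazin-2-yl in place of 4-methoxyphenyl on an aromatic carbon. Within the data shown here, no measured pair shows the effect of such a change, so the step is expected to be small, leaning toward a higher number, and is estimated as a 1.4-fold higher number from compound 3 to compound 4 (0.15 log units; within the scatter). On that basis compound 4 is expected to give 2200 nM, with a range from 800 nM to 6000 nM.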

Compound 4, half-maximal inhibitory concentration: 1430 nM
Compound 4: middle estimate off by 1.5-fold (0.19 log units), on the high side; measured number inside the range.
By their numbers in this assay, from the lowest: compounds 4, 3, 2 and 1 (each within the scatter of the next, the first and the last beyond it).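

In this assay, the first pair differing in one place gives a 1.1-fold lower number from compound 3 to compound 4 (0.03 log units; within the scatter), so pyrazin-2-yl and 4-methoxyphenyl on this aromatic carbon cannot be told apart. At this position, a six-membered aromatic ring of carbon only and one with 2 hetero atoms thus give matching numbers, despite the different heavy-atom counts. No measurement offered here accounts for this match. Going by these compounds, what an amine or a carboxylic acid on this carbon would do remains open. So does whether a pyridin-2-yl group would also match.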